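A few compounds are considered here, and "the series" means these few. Any claim that something is new, unique, unknown or untested is made for them only; others in the source may bear on it.

Measured so far:

Compound 1, `COc1cc(-c2[nH]c(=S)[nH]c(=O)c2C#N)cc(OC)c1OC`: in an ADME assay on THP-1 cells (Homo sapiens) for inhibition, read by MTT assay (a lower number here means a stronger inhibitor of growth, a higher number a weaker inhibitor of growth), compound 1 reaches only the assay limit, > 100 ug/mL.
Compound 2, `CCCc1cc2c(=O)n(CCCSc3nc(-c4cc(OC)c(OC)c(OC)c4)c(C#N)c(=O)[nH]3)cnc2s1`: in this assay compound 2 likewise reaches only the assay limit, > 100 ug/mL.
Compound 3, `CCCCCCCc1cc2c(=O)n(CCSc3nc(-c4cc(OC)c(OC)c(OC)c4)c(C#N)c(=O)[nH]3)cnc2s1`: in this assay compound 3 gives 88.1 ug/mL.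

Compound 2 thus stands at a limit rather than at a number, and compound 1 shares that position: the limit of > 100 ug/mL in this assay, at which 2 of the 3 values shown sit. Compound 3 is the only one of the three with an actual number, and that number lies close to the limit. Compound 4, `CCCCCCCc1cc2c(=O)n(CCCSc3nc(-c4cc(OC)c(OC)c(OC)c4)c(C#N)c(=O)[nH]3)cnc2s1`, has not yet been measured. Set against compound 2, the change is butyl in place of hydrogen on a saturated chain carbon, three bonds along the chain from an aromatic carbon. For the measured compounds named here, no step between measured compounds is available to calibrate such a change, so the expectation rests on the values as they stand. Since compound 3 gives 88.1 ug/mL, a longer chain of this kind has so far left the read-out high. The step from compound 2 to compound 4 is therefore expected to be small, an at least 1.0-fold lower number from compound 2 to compound 4 (0.02 log units; that floor lies within the scatter), within the usual scatter. Compound 4 is expected to come out around 95 ug/mL, between 45 ug/mL and 200 ug/mL, with a fair chance that only a limit is reported.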

Compound 4, concentration for 50% growth inhibition: 68.2 ug/mL
The estimate for compound 4 lay 1.4-fold (0.14 log units) above the measured number; the range from low to high includes it.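

In this assay, butyl in place of hydrogen on this saturated chain carbon, three bonds along the chain from an aromatic carbon, gives an at least 1.4-fold lower number from compound 2 to compound 4 (0.16 log units; that floor lies within the scatter). What this adds is that the heptyl chain of compound 4 yields an actual number where the propyl chain of compound 2 does not, although the floor alone cannot separate this change from the scatter. Compound 2 stands at a limit and not at a number, so the true size of the step stays unknown and may be larger than its floor: the limit of > 100 ug/mL in this assay, at which 2 of the 4 values shown sit.

From the compounds shown here alone, whether a longer chain such as decyl would move the number any further at this position remains open. So does what an amine or a carboxylic acid at the end of this chain would do.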